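Hydrazone tail variations on a shared anilino core

This account rests on a few compounds, and the source may have more. Where it says the series, first, only, none or still open, it means among the compounds named here.

Measured compounds:
Compound 1 `O=C(N/N=C/c1ccc(Br)cc1)N1CCc2ncnc(Nc3ccc(F)c(Cl)c3)c2C1` gives > 200000 nM, which is a limit of the assay.
Compound 2 `O=C(N/N=C/c1ccccc1)N1CCc2ncnc(Nc3ccc(F)c(Cl)c3)c2C1` gives 28800 nM.

In a functional assay on NCI-H1975 cells (Homo sapiens) for cytotoxicity, read by MTT assay, with a stated time of 72 h (on this read-out lower numbers stand for stronger inhibition and higher numbers for weaker inhibition), compound 2 holds the only true number shown, and the one other value is a limit. Among the measured compounds shown here, the single measured step is an at least 6.9-fold lower number from compound 1 to compound 2 (0.84 log units; beyond the scatter); its size is known only as a floor, since compound 1 sits at the limit of > 200000 nM in this assay, at which 1 of the 2 values shown sits. Compound 3 `O=C(N/N=C/c1cccc([N+](=O)[O-])c1)N1CCc2ncnc(Nc3ccc(F)c(Cl)c3)c2C1` is not yet measured. It differs from compound 2 by nitro in place of hydrogen on an aromatic carbon. The measured step concerns a different group, bromo, leaving the ring, so it bears only loosely on adding nitro; no shown step adds a group to this ring. The expected step is therefore small, a 1.4-fold higher number from compound 2 to compound 3 (0.14 log units; within the scatter), within or near the scatter, with a real chance of a limit. Compound 3 is estimated at 40000 nM, ranging from 10000 nM to 200000 nM.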

Compound 3, half-maximal inhibitory concentration: 86900 nM
Estimate against measurement, compound 3: 2.2-fold (0.34 log units) below, within the range that was stated.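

Adding a nitro group to the plain phenyl ring, meta to a large group, is the first direct look at a group entering this ring, and in this assay it gives a 3.0-fold higher number from compound 2 to compound 3 (0.48 log units; beyond the scatter). So a substituent on this ring can raise the number without reaching the limit of the assay, as the swap of 4-bromophenyl for 3-nitrophenyl shows, with an at least 2.3-fold lower number from compound 1 to compound 3 (0.36 log units; beyond the scatter). That step is known only as a floor because compound 1 gives a limit and not a number: the limit of > 200000 nM in this assay, at which 1 of the 3 values shown sits.

Going by these compounds, whether an amine or a methoxy group on this ring would also raise the number remains open. The bromo and nitro rings differ in both the group and its place, so the compounds shown cannot separate the two.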